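Quinone series: removing the (carboxymethyl)amino group

The source may hold more compounds than are shown below. What is called first, only, known or untested is meant among the compounds shown, and "the series" means these compounds.

Measured so far:
Compound 1 `CC1=CCC[C@H]2[C@](C)(CC3=CC(=O)C=C(NCCC(=O)O)C3=O)[C@@H](C)CC[C@]12C`: in an ADME assay on MRC5 cells (Homo sapiens) for cytotoxicity, read by MTT assay, with a stated time of 72 h (a higher number here means a weaker inhibitor, a lower number a stronger inhibitor), compound 1 gives 80800 nM.
Compound 2 `CC(C)(C)C1=CC(=O)C=C(NCC(=O)O)C1=O`: compound 2 gives > 200000 nM, a limit of the assay.
Compound 3 `CC(C)[C@@H](NC1=CC(=O)C=C(C(C)(C)C)C1=O)C(=O)O`: compound 3 gives > 200000 nM, also a limit of the assay.

Compound 2 stands at the limit of > 200000 nM in this assay, at which 2 of the 3 values shown sit, so its place among the numbers is not fixed. Among the measured compounds shown here, the one step out of it, a step that the two limits leave unreadable from compound 2 to compound 3, cannot be read for the same reason.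

Compound 4 `CC(C)(C)C1=CC(=O)C=CC1=O` differs from compound 2 by hydrogen in place of (carboxymethyl)amino on a double-bonded ring carbon. No measured step covers this change, and the only step from compound 2 rests on a limit, so nothing shown gives a size or direction to expect in this assay. Compound 4 is therefore estimated at 60000 nM with a range from 15000 nM to 250000 nM, meaning an expected step of an at least 3.3-fold lower number from compound 2 to compound 4 (0.52 log units; beyond the scatter), and a real chance that only a limit is reported again.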

Compound 4, half-maximal inhibitory concentration: > 200000 nM
Compound 4: no number, only a limit (the forecaster's own chance of this, stated with the estimate: 30%); middle value at least 3.3-fold (0.52 log units) away from the limit.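

Among the compounds shown here, compound 2 and compound 4 both give only a limit in this assay, so no step between them can be read: the limit of > 200000 nM in this assay, at which 3 of the 4 values shown sit. On these data alone, the size and direction of replacing (carboxymethyl)amino with hydrogen remain open.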